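Acetyl for Cyano on a Phenylpiperazine Amide

The source may hold more compounds than are shown below. What is called first, only, known or untested is meant among the compounds shown, and "the series" means these compounds.

Measured compounds:
compound 1, `COc1ccc2oc(N3CCN(CCCCCC(=O)NC4CCCc5ccccc54)CC3)nc2c1`: 704 nM
compound 2, `N#Cc1ccc(N2CCN(CCCCCC(=O)NC3CCCc4ccccc43)CC2)cc1`: 1400 nM

Going by the values given here, in an assay on HEK293 cells for displacement of a labelled ligand from 5-hydroxytryptamine receptor 7 (Rattus norvegicus) (on this read-out lower numbers stand for stronger inhibition and higher numbers for weaker inhibition), compound 2 gives 1400 nM, the highest of the two numbers; its only neighbour is compound 1, and the single measured step, a 2.0-fold higher number from compound 1 to compound 2 (0.30 log units; within the scatter), lies within the scatter. Compound 3, `CC(=O)c1ccc(N2CCN(CCCCCC(=O)NC3CCCc4ccccc43)CC2)cc1`, is not yet measured. It differs from compound 2 by acetyl in place of cyano on an aromatic carbon. Among the compounds with values here, no measured step bears directly on this exchange: the one step known swaps the whole group on the amine nitrogen of the ring, and even that stayed within the scatter. With no evidence for a shift in either direction, the expectation is no step beyond the scatter. Compound 3 is therefore estimated at 1200 nM, with a range from 400 nM to 4000 nM, which means an expected step of a 1.2-fold lower number from compound 2 to compound 3 (0.07 log units; within the scatter).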

Compound 3, inhibition constant: 2640 nM
Compound 3: middle estimate off by 2.2-fold (0.34 log units), on the low side; the range from low to high includes it.
By their numbers in this assay, from the lowest: compounds 1, 2 and 3 (each within the scatter of the next, the first and the last beyond it).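

In this assay, acetyl in place of cyano on the aromatic carbon gives a 1.9-fold higher number from compound 2 to compound 3 (0.28 log units; within the scatter), so at this site, para to a large group, the two groups cannot be told apart. The wider exchange on the amine nitrogen in the ring gives a 3.8-fold higher number from compound 1 to compound 3 (0.57 log units; beyond the scatter), a modest step and the first in this set beyond the scatter, which shows that 4-acetylphenyl and 5-methoxy-1,3-benzoxazol-2-yl can be told apart. Nothing available explains either step.

As far as these compounds go, it remains open whether an amine or a carboxylic acid on the same aromatic carbon would move the number beyond the scatter. From the compounds shown here alone, it is also open whether a shorter chain in the shared core would change how these groups compare.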